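This account rests on a few compounds, and the source may have more. Where it says the series, first, only, none or still open, it means among the compounds named here.

Measured in a functional assay on C8166 cells (Homo sapiens) for cytotoxicity, read by MTT assay, with a stated time of 72 h; on this read-out higher numbers stand for lower toxicity in this test and lower numbers for higher toxicity in this test:
- compound 1 `Cc1ccc(S(=O)(=O)N2CC3(C[C@H]2C(=O)N/N=C/c2ccccc2[N+](=O)[O-])SCCS3)cc1`: 65000 nM
- compound 2 `COc1ccc(/C=N/NC(=O)Cn2c(=O)c(C)nc3ccccc32)cc1OC`: > 526000 nM, a limit of the assay

Among the measured compounds shown here, compound 1 therefore holds the only actual number so far, and nothing yet ranks it. Compound 3 `Cc1ccc(S(=O)(=O)N2CC3(C[C@H]2C(=O)N/N=C/c2ccccc2F)SCCS3)cc1` keeps the core of compound 1 and differs by fluoro in place of nitro on an aromatic carbon in one place: fluoro in place of nitro on an aromatic carbon, ortho to a large group. For the measured compounds named here, no measured pair shows this change. The expected 1.3-fold higher number from compound 1 to compound 3 (0.12 log units; within the scatter) stays within the usual scatter, with no firm direction. For compound 3 the estimated value is 85000 nM, with an expected range of 30000 nM to 250000 nM.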

Compound 3, half-maximal cytotoxic concentration: 280000 nM
Compound 3: middle estimate off by 3.3-fold (0.52 log units), on the low side; the measured number lies above the stated range.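

In this assay, among the compounds shown here, the aromatic carbon ortho to a large group proves sensitive to substitution, giving the first readable step: a 4.3-fold higher number from compound 1 to compound 3 (0.63 log units; beyond the scatter). With the core of compound 1 kept, the 2-nitrophenyl to 2-fluorophenyl change alone is enough to shift the read-out towards lower toxicity in this test. No information given here accounts for the size of this step.

Only nitro and fluoro are shown at this position, so no trend can be drawn from a single pair. From the compounds shown here alone, whether an amine or a carboxylic acid there would fall nearer compound 1 or compound 3 remains open.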